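Replacing a Hydroxybutyl Chain with a Difluorophenyl Ring

The source may hold more compounds than are shown below. What is called first, only, known or untested is meant among the compounds shown, and "the series" means these compounds.

Measured so far, in a functional assay on HeLa cells (Homo sapiens) for inhibition, read by MTT assay, with a stated time of 72 h; on this read-out higher numbers stand for weaker inhibition and lower numbers for stronger inhibition:
compound 1, `CC(O)c1cn(Cc2cc(=O)oc3cc(O)ccc23)nn1`: > 100000 nM
compound 2, `O=c1cc(Cn2cc(CCCCO)nn2)c2ccc(O)cc2o1`: > 100000 nM

Both values are limits of the assay rather than numbers. For compound 1 the reading > 100000 nM is such a limit. For compound 2 the reading > 100000 nM is likewise a limit. The step that the two limits leave unreadable from compound 1 to compound 2 therefore cannot be read, because of the limit of > 100000 nM in this assay, at which 2 of the 2 values shown sit. Compound 2 thus stands at the limit of this assay, and nothing more precise can be said of where it lies.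

Compound 3, `O=c1cc(Cn2cc(-c3cc(F)cc(F)c3)nn2)c2ccc(O)cc2o1`, differs from compound 2 by 3,5-difluorophenyl in place of 4-hydroxybutyl on an aromatic carbon. Within the data shown here, the only measured step, the one from compound 1 to compound 2, touches the same place on the shared core but is unreadable, so its size gives no guidance on how a change there shifts the result. No step beyond the scatter can be foreseen in either direction. Compound 3 is expected to give 100000 nM, within the range 20000 nM to 300000 nM. The expected step of a number no higher from compound 2 to compound 3 (the limit leaves the size open) rests on nothing more than the two limits already shown.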

Compound 3, half-maximal inhibitory concentration: 27600 nM
Compound 3: the middle estimate sits 3.6-fold (0.56 log units) above what was measured, within the range that was stated.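

In this assay, 3,5-difluorophenyl in place of 4-hydroxybutyl gives an at least 3.6-fold lower number from compound 2 to compound 3 (0.55 log units; beyond the scatter), the first readable sign that this carbon of the five-membered aromatic ring responds to what it carries. Replacing 1-hydroxyethyl at the same place with 3,5-difluorophenyl gives an at least 3.6-fold lower number from compound 1 to compound 3 (0.55 log units; beyond the scatter), so the aromatic ring with its two fluorines gives a lower number than either of these two open chains, each of which bears a hydroxyl group. The full size of both steps cannot be read because each starts from a limit rather than a number: the limit of > 100000 nM in this assay, at which 2 of the 3 values shown sit.

The compounds shown do not separate the part played by the six-membered aromatic ring from that of its two fluorine atoms, a question that an unsubstituted phenyl ring at this place would address directly. They also leave open how other groups would behave here, such as a pyridine ring, an amine or a carboxylic acid, and whether any of them would lower the number further.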